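The source may report more compounds than this note shows. Statements on the series, on what has been measured and on what is new or still open speak of the compounds shown alone.

Measured so far in a functional assay on MDA-MB-231 cells (Homo sapiens) for inhibition, read by MTT assay, with a stated time of 24 h, tested at 100 uM; a higher number here means more inhibition at the concentration tested (going by the name of the read-out), a lower number less inhibition:
- compound 1 `N#Cc1cccc(/C=N/NC(=O)c2ccc(O[C@@H]3O[C@H](CO)[C@@H](O)[C@H](O)[C@H]3O)cc2)c1` gives 6.17%
- compound 2 `CCCCCc1nnc(-c2ccc(O[C@@H]3O[C@H](COC(C)=O)[C@@H](OC(C)=O)[C@H](OC(C)=O)[C@H]3OC(C)=O)cc2)o1` gives 21.5%
- compound 3 `CC(=O)OC[C@H]1O[C@@H](Oc2ccc(-c3nnc(-c4ccc([N+](=O)[O-])cc4)o3)cc2)[C@H](OC(C)=O)[C@@H](OC(C)=O)[C@@H]1OC(C)=O` gives 58%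

Compound 1 stands lowest of the three numbers in this assay; compound 2 lies nearest, and compound 3 furthest, both beyond the scatter. Within the data shown here, the one step in the set that changes a single place is a number 36.5 percentage points higher from compound 2 to compound 3 (beyond the scatter), a change on a different core than that of compound 1, so it gives no direct guide here.

Compound 4 `O=C(N/N=C/c1cccc(Cl)c1)c1ccc(O[C@@H]2O[C@H](CO)[C@@H](O)[C@H](O)[C@H]2O)cc1` differs from compound 1 in one place: chloro in place of cyano on an aromatic carbon. Among the measured compounds shown here, no measured pair shows a chloro-for-cyano exchange, nor any other change on the core shared by compound 1 and compound 4. The expectation therefore rests on compound 1 alone, and the estimate for compound 4 is a step of a number 3.8 percentage points higher from compound 1 to compound 4 (within the scatter), that is, no step beyond the scatter. Compound 4 is thus estimated at 10% in this assay, with a range from 0% to 28%.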

Compound 4, a percentage reported as inhibition, at one concentration (the size of the read-out at that concentration, not a potency): 5.02%
Compound 4: middle estimate off by 5 percentage points, on the high side; measured number inside the range.
By their numbers in this assay, from the lowest: compounds 4 and 1 (each within the scatter of the next); then compound 2; then compound 3.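

In this assay, among these compounds, the step of a number 1.2 percentage points lower from compound 1 to compound 4 (within the scatter) is the first one read on the shared core, and it shows that chloro can stand in place of cyano at this place, on an aromatic carbon meta to a large group, with no change beyond the scatter. The read-out comes from one concentration and is no potency, so the exchange of 3-cyanophenyl for 3-chlorophenyl gives no ranking of the two compounds. No evidence on record bears on this result.

Whether any group at this place can move the number on the shared core stays open, since an amine, a carboxylic acid and a longer chain have no values among the compounds shown. The acetate esters carried by compound 2 and compound 3 also remain unread on the core of compound 1.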